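Cyano in Place of Fluoro on a Cytotoxicity Series

The source may hold more compounds than are shown below. What is called first, only, known or untested is meant among the compounds shown, and "the series" means these compounds.

Measured in a functional assay on Huh-7 cells (Homo sapiens) for cytotoxicity, with a stated time of 48 h; a lower number here means a stronger inhibitor, a higher number a weaker inhibitor:
compound 1 `O=[N+]([O-])c1ccc(CN2CCC(n3cc(CC(OCc4cc(-c5ccccc5)no4)c4ccc(Br)cc4)nn3)CC2)cc1` gives 7000 nM
compound 2 `O=[N+]([O-])c1ccc(CN2CCC(n3cc(CC(OCc4cc(-c5ccc(F)cc5)no4)c4ccc(Br)cc4)nn3)CC2)cc1` gives 2000 nM
compound 3 `O=[N+]([O-])c1ccc(CN2CCC(n3cc(CC(OCc4cc(-c5cccc(F)c5)no4)c4ccc(Br)cc4)nn3)CC2)cc1` gives 3000 nM

Among these three numbers, compound 3 stands second highest. Its nearest neighbour is compound 2, a 1.5-fold higher number from compound 2 to compound 3 (0.18 log units; within the scatter). Its furthest is compound 1, a 2.3-fold lower number from compound 1 to compound 3 (0.37 log units; beyond the scatter).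

Compound 4 `N#Cc1cccc(-c2cc(COC(Cc3cn(C4CCN(Cc5ccc([N+](=O)[O-])cc5)CC4)nn3)c3ccc(Br)cc3)on2)c1` differs from compound 3 in one place: cyano in place of fluoro on an aromatic carbon. Among the measured compounds shown here, the steps that bear on this change are the two that also alter the same phenyl ring: a 3.5-fold lower number from compound 1 to compound 2 (0.54 log units; beyond the scatter) and a 2.3-fold lower number from compound 1 to compound 3 (0.37 log units; beyond the scatter). Both are modest, and the only one at the same position, the step from compound 1 to compound 3, is barely beyond the scatter. For the measured compounds named here, no measured step introduces a cyano group, so nothing shows how this particular group behaves here. On that basis a step of about the same small size is expected in this assay, no change at the digits printed from compound 3 to compound 4 (within the scatter), with no confident direction.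

Compound 4 is therefore estimated at 3000 nM, with a range from 1000 nM to 9000 nM.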

Compound 4, half-maximal inhibitory concentration: 3000 nM
Estimate against measurement, compound 4: no gap at the digits printed; the range from low to high includes it.
By their numbers in this assay, from the lowest: compounds 2, 3 and 4 (each within the scatter of the next); then compound 1.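

In this assay, replacing the 3-fluorophenyl with a 3-cyanophenyl gives no change at the digits printed from compound 3 to compound 4 (within the scatter), so at this position a nitrile of two heavy atoms gives the same number as a single fluorine. The step of a 1.5-fold higher number from compound 2 to compound 4 (0.18 log units; within the scatter) also stays within the scatter, while a 2.3-fold lower number from compound 1 to compound 4 (0.37 log units; beyond the scatter) is a modest move beyond it, so compound 4 groups with the two fluoro compounds and apart from compound 1, which has hydrogen on this carbon. Nothing measured here explains why fluoro and cyano give matching numbers.

From the compounds shown here alone, it remains open whether this match would hold for an amine or a carboxylic acid on the same aromatic carbon. A longer chain there might also move the number beyond the scatter, and the compounds shown cannot settle that either.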